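The source may hold more compounds than are shown below. What is called first, only, known or untested is meant among the compounds shown, and "the series" means these compounds.

Of the compounds shown here, three sharing one core have been measured in an assay on cells for displacement of a labelled ligand from corticotropin-releasing factor receptor 1 (Homo sapiens), with a stated time of 100 min; a lower number here means a stronger inhibitor, a higher number a weaker inhibitor. Compound 1, `CCN(Cc1c(C(F)(F)F)nc2n(-c3c(C)cc(C)cc3C)c(Cl)cn12)CC1CC1`, gives 9 nM. Compound 2, `C=C(C)CN(CC)Cc1c(C(F)(F)F)nc2n(-c3c(C)cc(C)cc3C)c(Cl)cn12`, gives 67 nM. Compound 3, `CCN(CCC1CC1)Cc1c(C(F)(F)F)nc2n(-c3c(C)cc(C)cc3C)c(Cl)cn12`, gives 13 nM, which places it second highest of the three; it sits within the usual scatter of compound 1 and well apart from compound 2.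

The steps among these three all concern the group on a saturated chain carbon bound to the amine nitrogen. There was a 7.4-fold higher number from compound 1 to compound 2 (0.87 log units; beyond the scatter), while a 1.4-fold higher number from compound 1 to compound 3 (0.16 log units; within the scatter), and a 5.2-fold lower number from compound 2 to compound 3 (0.71 log units; beyond the scatter).

Compound 4, `Cc1cc(C)c(-n2c(Cl)cn3c(CN4CCC(C)CC4)c(C(F)(F)F)nc23)c(C)c1`, has not yet been measured. It differs from compound 3 in this way: 4-methylpiperidin-1-yl in place of (2-cyclopropylethyl)(ethyl)amino on a saturated chain carbon bound to an aromatic carbon. Here the open-chain amine is exchanged for a ring amine, a change none of the measured steps mirrors directly. The measured steps show that reshaping the amine substituent can shift this assay modestly, as with compound 2, or hardly at all, as with compound 3. Among the measured compounds shown here, with no closer precedent, a modest loss of potency is expected, a 2.3-fold higher number from compound 3 to compound 4 (0.36 log units; beyond the scatter). Compound 4 is therefore estimated at 30 nM, with a plausible range from 8 nM to 120 nM.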

Compound 4, inhibition constant: 3200 nM
Estimate against measurement, compound 4: 110-fold (2.03 log units) below; the whole stated range lies below it.
By their numbers in this assay, from the lowest: compounds 1 and 3 (each within the scatter of the next); then compound 2; then compound 4.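

In this assay, replacing an open-chain amine with 4-methylpiperidin-1-yl on a saturated chain carbon bound to an aromatic carbon is far from neutral: there is a 250-fold higher number from compound 3 to compound 4 (2.39 log units; beyond the scatter), along with a 360-fold higher number from compound 1 to compound 4 (2.55 log units; beyond the scatter) and a 48-fold higher number from compound 2 to compound 4 (1.68 log units; beyond the scatter). The earlier compounds shown here all kept an ethyl group and a second open chain on the amine nitrogen, and the largest change among them was a 7.4-fold higher number from compound 1 to compound 2 (0.87 log units; beyond the scatter), so they showed only a modest sensitivity to reshaping one chain, whereas compound 4 shows that this position can respond much more strongly when both chains give way to a single ring. No supporting evidence bears on why the number rises so steeply.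

The compounds shown cannot separate the effect of having a ring at all from that of the methyl group on it, and a plain piperidin-1-yl or a morpholin-4-yl at the same place would help to tell these apart. On these data alone, it also remains open whether open-chain amines without the ethyl group, such as a dipropylamino group, would stay close to compound 1 and compound 3.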